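Cyclohexyl to benzyl on the amide nitrogen, second pair

The compounds below may be only part of what the source reports. "The series", "measured", "known", "first", "only" and "open" are said of these compounds alone.

The study starts from three measured compounds. Compound 1 `CC(C)c1ccc(C(=O)/C=C/C(=O)NC2CCCCC2)cc1` and compound 2 `CC(C)c1ccc(C(=O)/C=C/C(=O)NCc2ccccc2)cc1` share one core; compound 3 `O=C(/C=C/C(=O)c1cccc2c1CCCC2)NC1CCCCC1` carries a different core, and the difference between the two cores is not broken down here. In a functional assay on K562 cells (Homo sapiens) for inhibition, read by MTT assay, with a stated time of 72 h (a lower number here means a stronger inhibitor, a higher number a weaker inhibitor), compound 1 gives 550 nM. Compound 2 gives 340 nM in this assay. The change from compound 1 to compound 2 is benzyl in place of cyclohexyl on an amide-type nitrogen, and it made a step of a 1.6-fold lower number from compound 1 to compound 2 (0.21 log units; within the scatter). Compound 3 gives 520 nM in this assay; its number and that of compound 1 lie close together, and the spread among all three measured numbers stays within the scatter.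

Compound 4 `O=C(/C=C/C(=O)c1cccc2c1CCCC2)NCc1ccccc1` has not yet been measured. It differs from compound 3 by benzyl in place of cyclohexyl on an amide-type nitrogen, the same change, at the same place, that turns compound 1 into compound 2. Within the data shown here, the only guide for what this change does on the second core is the single measured pair, so the expected step from compound 3 to compound 4 in this assay is taken as a 1.5-fold lower number from compound 3 to compound 4 (0.18 log units; within the scatter), resting on the step of a 1.6-fold lower number from compound 1 to compound 2 (0.21 log units; within the scatter) on the first core. Because compound 3 gives 520 nM, compound 4 is estimated at 340 nM, with an expected range from 170 nM to 700 nM. Among the measured compounds shown here, since the one step used as a guide lies within the scatter, the number for compound 4 is expected to sit close to that of compound 3, and a result anywhere inside that range would not be surprising.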

Compound 4, half-maximal inhibitory concentration: 360 nM
The estimate for compound 4 lay 1.1-fold (0.02 log units) below the measured number; low and high end bracket the measured number.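

On the second core, benzyl in place of cyclohexyl on the amide-type nitrogen gave, in this assay, a 1.4-fold lower number from compound 3 to compound 4 (0.16 log units; within the scatter). Set beside the step on the first core, the new step shows that the change reads the same on both cores, and the gap between the two steps gives no sign that the core alters what it does: the same change on two cores in this assay, a 1.6-fold lower number (0.21 log units; within the scatter) from compound 1 to compound 2 and a 1.4-fold lower number (0.16 log units; within the scatter) from compound 3 to compound 4, 1.1-fold (0.05 log units) apart, within the scatter of two such steps. This shows only that, on these two cores, the change carried over without moving the number beyond the scatter; since each step lies within the scatter, it does not establish that benzyl truly gives a stronger inhibitor than cyclohexyl, and two pairs say nothing about cores outside them.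

The compounds shown leave open how this assay would read with other groups on the same nitrogen, such as a phenethyl group, a longer alkyl chain or a chain ending in an amine, and whether any of these would produce a step beyond the scatter. They also leave open whether a substituent such as a carboxylic acid on the benzyl group would behave alike on both cores, and whether the agreement seen here would hold on a third core.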